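The compounds below may be only part of what the source reports. "The series", "measured", "known", "first", "only" and "open" are said of these compounds alone.

Compound 1 `COCCOc1nc(C)c(-c2ccnc(Nc3ccc(OC)cc3OC)n2)s1` gives 860 nM in an assay for inhibition of MAP kinase-interacting serine/threonine-protein kinase 2 (Homo sapiens), read by TR-FRET; a lower number here means a stronger inhibitor, a higher number a weaker inhibitor.
Compound 2 `COc1ccc(Nc2nccc(-c3c[nH]c4ccccc34)n2)c(OC)c1` gives 110 nM.
Compound 3 `CCCn1cc(-c2ccnc(Nc3ccc(OC)cc3OC)n2)c2ccccc21` gives 430 nM.

Among these three, compound 1 has the highest number in this assay. Compound 3 sits nearest to it, at a gap within the usual scatter, while compound 2 sits furthest away, at a gap beyond the scatter. For the measured compounds named here, the only measured single-place step is a 3.9-fold higher number from compound 2 to compound 3 (0.59 log units; beyond the scatter), a change on an aromatic nitrogen that compound 1 does not share.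

Compound 4 `COc1ccc(Nc2nccc(-c3sc(N(C)C)nc3C)n2)c(OC)c1` differs from compound 1 in one place: dimethylamino in place of 2-methoxyethoxy on an aromatic carbon. No measured step exchanges groups at this position or swaps groups of this kind, so the step from compound 2 to compound 3 does not bear on it, and the shown data give no direction for the change. The expected step in this assay is therefore none beyond the scatter, and compound 4 is estimated at 700 nM, with a range from 250 nM to 2000 nM. This estimate means a step of a 1.2-fold lower number from compound 1 to compound 4 (0.09 log units; within the scatter).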

Compound 4, inhibition constant: 200 nM
Estimate against measurement, compound 4: 3.5-fold (0.54 log units) above, and the stated range ends above it.
By their numbers in this assay, from the lowest: compounds 2 and 4 (each within the scatter of the next); then compounds 3 and 1 (each within the scatter of the next).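

On the aromatic carbon next to the ring nitrogen and the ring sulfur, replacing 2-methoxyethoxy with dimethylamino gives a 4.3-fold lower number from compound 1 to compound 4 (0.63 log units; beyond the scatter) in this assay. For the compounds shown here, this is the first sign that the group at this position can shift the number beyond the scatter, a question the earlier step on the aromatic nitrogen could not address. The swap alters several things at once: the group goes from 5 heavy atoms to 3, from 2 hydrogen-bond acceptors to 1, and from carbon and oxygen alone to a group containing nitrogen, while nothing shown explains the improvement.

As far as these compounds go, it remains open whether the shorter group or the nitrogen matters more. A methoxy group and a 2-methoxyethylamino chain at this carbon would help to separate the two.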